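Swapping a Methyl for a Nitrile on the Aryl Arm

The source may hold more compounds than are shown below. What is called first, only, known or untested is meant among the compounds shown, and "the series" means these compounds.

Measured so far:
compound 1 `CCc1ccc(-c2nc3c(c(C)nn3-c3ccccc3)c(-c3ccccc3[N+](=O)[O-])c2C#N)cc1`: 1200 nM
compound 2 `Cc1cccc(-c2nc3c(c(C)nn3-c3ccccc3)c(-c3ccccc3O)c2C#N)c1`: 42000 nM

For the measured compounds named here, in a physicochemical assay for solubility, read by spectrophotometry, in phosphate buffer, with a stated time of 18 h, at pH 7.4 (a lower number here means a less soluble compound, a higher number a more soluble compound), compound 2 gives the higher of the two numbers, and the only neighbour, compound 1, sits far lower, beyond the scatter. Compound 3 `Cc1nn(-c2ccccc2)c2nc(-c3ccc(C#N)cc3)c(C#N)c(-c3ccccc3O)c12` differs from compound 2 in one place: 4-cyanophenyl in place of 3-methylphenyl on an aromatic carbon. Going by the values given here, no pair of measured compounds covers this change, so nothing in the data sets its size. The step of a 1.1-fold lower number from compound 2 to compound 3 (0.02 log units; within the scatter) is expected to stay within the scatter, with no clear direction. Compound 3 is therefore estimated at 40000 nM in this assay, with a range from 12000 nM to 130000 nM.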

Compound 3, solubility: 1700 nM
The estimate for compound 3 lay 24-fold (1.37 log units) above the measured number, outside the stated range (below it).
By their numbers in this assay, from the lowest: compounds 1 and 3 (each within the scatter of the next); then compound 2.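

In this assay, the aryl arm on this aromatic carbon proves far from neutral: 4-cyanophenyl in place of 3-methylphenyl gives a 25-fold lower number from compound 2 to compound 3 (1.39 log units; beyond the scatter), a large step from one swap. For the compounds shown here, no earlier pair differed in only one place, so this is the first direct reading of this position. Nothing measured here explains the step.

Which part of the swap carries the step, the nitrile or where the substituent sits on the phenyl ring, stays open. Also open, from the compounds shown here alone, is how an aryl arm bearing an amine or a carboxylic acid would read.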